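Cytotoxicity of Selenium- and Sulfur-Bridged Bis-Amides on PC-3 Cells

The source may hold more compounds than are shown below. What is called first, only, known or untested is meant among the compounds shown, and "the series" means these compounds.

Measured compounds:
compound 1 `O=C(/N=C(/NC(=O)c1cc(-c2ccccc2)nc2ccccc12)[Se]Cc1ccccc1)c1cc(-c2ccccc2)nc2ccccc12`, > 100000 nM
compound 2 `O=C(/N=C(/NC(=O)c1cccs1)[Se]Cc1ccccc1)c1cccs1`, > 100000 nM
compound 3 `CS/C(=N\C(=O)c1cccs1)NC(=O)c1cccs1`, > 100000 nM

In a functional assay on PC-3 cells (Homo sapiens) for cytotoxicity, read by MTT assay, with a stated time of 72 h (on this read-out lower numbers stand for higher toxicity in this test and higher numbers for lower toxicity in this test), compound 1 reaches only a limit of the assay, > 100000 nM. In this assay compound 2 likewise gives a limit, > 100000 nM. In this assay compound 3 also stays at a limit, > 100000 nM. The difference between the cores of compound 1 and compound 2 is not broken down here.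

From compound 2 to compound 3 the change is a group of 2 heavy atoms (1 carbon, 1 sulfur; no ring) in place of a group of 8 heavy atoms (7 carbon, 1 selenium; one six-membered aromatic ring of carbon only), on a carbon with a double bond to nitrogen, and the two limits leave its size unreadable: a step that the two limits leave unreadable from compound 2 to compound 3. The same change turns compound 1 into compound 4 `CS/C(=N\C(=O)c1cc(-c2ccccc2)nc2ccccc12)NC(=O)c1cc(-c2ccccc2)nc2ccccc12`, namely (a group of 2 heavy atoms (1 carbon, 1 sulfur; no ring) in place of a group of 8 heavy atoms (7 carbon, 1 selenium; one six-membered aromatic ring of carbon only), on a carbon with a double bond to nitrogen). Since all three measured values sit at the limit (the limit of > 100000 nM in this assay, at which 3 of the 3 values shown sit), a step of similar unreadable size is expected here too, a step that the limit leaves unreadable from compound 1 to compound 4. Compound 4 is therefore estimated at 200000 nM, most likely reported again only as a limit in this assay.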

Compound 4, concentration lethal to 50% of the cells: > 100000 nM
Compound 4: no number, only a limit; the forecaster's own chance of this, stated with the estimate: 85%; the middle value does not contradict the limit.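

Compound 1 and compound 4 both stay at a limit in this assay, and no step can be read between them. The compounds shown leave open whether methylsulfanyl in place of the selenium-bearing group changes toxicity at all: the limit of > 100000 nM in this assay, at which 4 of the 4 values shown sit.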